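Chain length at the sulfur: from compound 3 to compound 4

The compounds below may be only part of what the source reports. "The series", "measured", "known", "first", "only" and "open" are said of these compounds alone.

Measured so far in a functional assay on the whole organism (strain NMRI) with Mus musculus as the target, with a stated time of 60 min, at a dose of 5 mg/kg by the intraperitoneal route; on this read-out higher numbers stand for a stronger effect at the one dose given and lower numbers for a weaker effect:
Compound 1 `CCCSc1nnc(Cc2ccc(Cl)cc2Oc2ccccc2Cl)[nH]1`: 118%
Compound 2 `CSc1nnc(Cc2ccc(Cl)cc2Oc2ccccc2F)[nH]1`: 110%
Compound 3 `CCSc1nnc(Cc2ccc(Cl)cc2Oc2ccccc2F)[nH]1`: 126%

Compound 3 gives the highest of the three numbers in this assay; compound 1 lies within the scatter of it, only compound 2 sits beyond the scatter below it. Compound 4 `CCCSc1nnc(Cc2ccc(Cl)cc2Oc2ccccc2F)[nH]1` is not yet measured. Going by the values given here, it differs from compound 3 by methyl in place of hydrogen on a saturated chain carbon, two bonds along the chain from a sulfur, the same kind of lengthening as the one step seen so far, a number 16 percentage points higher from compound 2 to compound 3 (beyond the scatter). Compound 1, which carries the propyl chain, and compound 3 show values within the scatter of each other, so the chain lengthening is not expected to carry a further clear step. For compound 4 the expected value is 122% (range 105% to 140%), an expected step of a number 4 percentage points lower from compound 3 to compound 4 (within the scatter), within the scatter.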

Compound 4, a percentage reported as activity, at one dose (the size of the read-out at that dose, not a potency): 119%
Estimate against measurement, compound 4: 3 percentage points above; low and high end bracket the measured number.
By their numbers in this assay, from the lowest: compounds 2, 1, 4 and 3 (each within the scatter of the next, the first and the last beyond it).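

In this assay, ethylsulfanyl to propylsulfanyl gives a number 7 percentage points lower from compound 3 to compound 4 (within the scatter) and methyl to propyl on the sulfur gives a number 9 percentage points higher from compound 2 to compound 4 (within the scatter), so of the chains in the fluoro series only ethyl stands clear of methyl, with a number 16 percentage points higher from compound 2 to compound 3 (beyond the scatter). With the propyl chain held constant, fluoro in place of chloro gives a number 1 percentage points higher from compound 1 to compound 4 (within the scatter), so this halogen change does not separate the pair. No supporting data bear on these readings. Still open, going by these compounds, is how a longer chain, such as butyl, would read on the sulfur. On these data alone, an amine or a carboxylic acid at the end of the chain is also open.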